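Antiproliferative benzothiazole amines: chloro to methyl on the pyridine

A few compounds are considered here, and "the series" means these few. Any claim that something is new, unique, unknown or untested is made for them only; others in the source may bear on it.

Values in a functional assay on HEp-2 cells (Homo sapiens) for antiproliferative activity, read by MTT assay, with a stated time of 72 h; a higher number here means a weaker inhibitor, a lower number a stronger inhibitor:

- compound 1, `N#Cc1ccc2nc(Nc3ccc(Cl)cn3)sc2c1`: a limit, > 10000 nM
- compound 2, `Cc1cccnc1Nc1nc2ccc(C#N)cc2s1`: a limit, > 10000 nM
- compound 3, `N#Cc1ccc2nc(Nc3ncccn3)sc2c1`: 5000 nM

Compound 1 gives only a limit in this assay, > 10000 nM, and not a number. Compound 2 likewise sits at a limit, > 10000 nM. Among the three measured compounds only compound 3 returns a number, 5000 nM, so compound 1 stands at the weak end of what is known, with its true value hidden behind (the limit of > 10000 nM in this assay, at which 2 of the 3 values shown sit).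

Compound 4, `Cc1ccc(Nc2nc3ccc(C#N)cc3s2)nc1`, has not been measured. It differs from compound 1 by methyl in place of chloro on an aromatic carbon. For the measured compounds named here, no step between measured compounds touches this position, so the size of the change is not known from the data. Because compound 1 sits at > 10000 nM, and because the other methyl-bearing compound 2 also sits at > 10000 nM, no shift beyond the scatter in either direction is expected.

Compound 4 is therefore estimated at 12000 nM, in the range 4000 nM to 35000 nM, which means an expected step that the limit leaves unreadable from compound 1 to compound 4, with a good chance that only a limit is again reported.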

Compound 4, half-maximal inhibitory concentration: > 10000 nM
Compound 4 ended at the assay's limit; the forecaster's own chance of this, stated with the estimate: 65%; the middle value is on the limit's open side.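

In this assay compound 4 gives > 10000 nM, which is a limit and not a number. For the compounds shown here, compound 1 gives > 10000 nM, also a limit, so no step between compound 1 and compound 4 can be read. The compounds shown leave open how far the true values of either compound lie from that limit, and whether methyl and chloro differ here at all.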